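A few compounds are considered here, and "the series" means these few. Any claim that something is new, unique, unknown or untested is made for them only; others in the source may bear on it.

Compound 1 `O=C(Nc1cccc(-n2cc(-c3ccncc3)c(-c3ccc(Cl)c(O)c3)n2)c1)Nc1ccc(Cl)c(Cl)c1` belongs to a small set of three analogues that share one core and differ only in the group hung from the amide-type nitrogen or the carbonyl carbon. In a functional assay on NCI-H522 cells (Homo sapiens) for inhibition, read by sulforhodamine B assay, with a stated time of 48 h (a lower number here means a stronger inhibitor of growth, a higher number a weaker inhibitor of growth), compound 1 gives 10600 nM. Compound 2 `COc1cc(-c2nn(-c3cccc(NC(=O)c4ccc(Cl)c(C(F)(F)F)c4)c3)cc2-c2ccncc2)ccc1Cl` gives 13400 nM in this assay, and compound 3 `COc1cc(-c2nn(-c3cccc(NC(=O)Nc4ccc(Cl)c(C(F)(F)F)c4)c3)cc2-c2ccncc2)ccc1Cl` gives 6060 nM. Compound 1 therefore sits with the second highest of the three numbers, and its distance to compound 2 and to compound 3 is within the scatter either way.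

Compound 4 `O=C(Nc1cccc(-n2cc(-c3ccncc3)c(-c3ccc(Cl)c(O)c3)n2)c1)Nc1cccc(C(F)(F)F)c1` differs from compound 1 in one place: 3-(trifluoromethyl)phenyl in place of 3,4-dichlorophenyl on an amide-type nitrogen. Among the measured compounds shown here, the only measured step in this assay, a 2.2-fold lower number from compound 2 to compound 3 (0.34 log units; beyond the scatter), concerns a different change, so nothing measured here speaks directly to swapping one substituted phenyl for another on the amide-type nitrogen. With all three measured numbers close together, the expectation for compound 4 is a step of a 1.1-fold lower number from compound 1 to compound 4 (0.03 log units; within the scatter), that is, none beyond the scatter. Compound 4 is thus estimated at 10000 nM, with a range from 4000 nM to 25000 nM.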

Compound 4, concentration for total growth inhibition: 14500 nM
Beside the measured number, compound 4's estimate is 1.5-fold (0.16 log units) below it, within the range that was stated.
By their numbers in this assay, from the lowest: compounds 3, 1, 2 and 4 (each within the scatter of the next, the first and the last beyond it).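

In this assay, putting 3-(trifluoromethyl)phenyl in place of 3,4-dichlorophenyl on the amide-type nitrogen gives a 1.4-fold higher number from compound 1 to compound 4 (0.14 log units; within the scatter) and so leaves the two groups indistinguishable here. Among the compounds shown here, this is the first measured comparison at this position, and it shows that a change from 8 to 10 heavy atoms, with chlorine replaced by fluorine, does not separate the pair in this growth read-out. No supporting measurement is available to explain this result.

From the compounds shown here alone, both groups at this position are phenyl rings carrying halogen-containing substituents, so the effect of an unsubstituted phenyl ring remains open. Going by these compounds, it is also open whether a phenyl ring bearing an amine or a carboxylic acid, or a short alkyl chain in place of the ring, would give a number that stands clear of the scatter.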